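The compounds below may be only part of what the source reports. "The series", "measured", "known", "first", "only" and "open" are said of these compounds alone.

Three compounds share one core and differ only in the group carried on an amine nitrogen. Compound 1 `O=C(/C=C\Nc1ccc2cc[nH]c2c1)c1nc(-c2ccc(C(F)(F)F)cc2)n2ccccc12` reaches only a limit of the method in a functional assay on A549 cells (Homo sapiens) for cytotoxicity, read by MTT assay, with a stated time of 48 h (a higher number here means a weaker inhibitor, a lower number a stronger inhibitor), and gives > 30000 nM. Compound 2 `O=C(/C=C\Nc1cnc2ccccc2c1)c1nc(-c2ccccc2)n2ccccc12` also stops at a limit in this assay, giving > 30000 nM. Compound 3 `O=C(/C=C\Nc1ccc(F)cc1)c1nc(-c2ccc(C(F)(F)F)cc2)n2ccccc12` stands at a limit as well, with > 30000 nM in this assay. The step that the two limits leave unreadable from compound 1 to compound 3 cannot be sized because of the limit of > 30000 nM in this assay, at which 3 of the 3 values shown sit. Compound 4 `O=C(/C=C\Nc1cnc2ccccc2c1)c1nc(-c2ccc(C(F)(F)F)cc2)n2ccccc12` carries the change quinolin-3-yl in place of 4-fluorophenyl on an amine nitrogen and has not yet been measured in this assay. Going by the values given here, no measured step gives a direction, so the expected step of a number no higher from compound 3 to compound 4 (the limit leaves the size open) is set at no change beyond the scatter. Compound 4 is therefore expected to give about 30000 nM, within 8000 nM to 100000 nM.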

Compound 4, half-maximal inhibitory concentration: > 30000 nM
Compound 4: a limit, no number; the forecaster's own chance of this, stated with the estimate: 80%; the middle value sits exactly at the limit.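

Compound 4, like compound 1, compound 2 and compound 3, stops at a limit, so none of the steps between them can be read: the limit of > 30000 nM in this assay, at which 4 of the 4 values shown sit. The compounds shown leave open whether any change to the shared core gives a measurable value in this assay at all.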